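The compounds below may be only part of what the source reports. "The series", "measured", "known", "first", "only" and "open" are said of these compounds alone.

Going by the values given here, compound 2 `COC(=O)c1nc(C)n(-c2ccc(OC)cc2)n1` is the only compound here with a number rather than a limit. In a functional assay on NPC-TW01 cells (Homo sapiens) for inhibition, read by MTT assay, with a stated time of 72 h (on this read-out higher numbers stand for weaker inhibition of growth and lower numbers for stronger inhibition of growth), compound 2 gives 9920 nM. Compound 1 `COC(=O)c1nc(C)n(-c2ccc(C(F)(F)F)cc2)n1` differs from it only in carrying a trifluoromethyl group where compound 2 carries methoxy. In this assay compound 1 reaches only a limit, > 100000 nM. Moving from that limit to the number of compound 2 is an at least 10-fold lower number from compound 1 to compound 2 (1.00 log units; beyond the scatter), and the size of that step is uncertain because one end of it is the limit of > 100000 nM in this assay, at which 1 of the 2 values shown sits.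

Compound 3 `COC(=O)c1nc(C)n(-c2ccc(Cl)cc2)n1` carries a chloro group in place of methoxy: chloro in place of methoxy on an aromatic carbon. Among the compounds with values here, the one measured step shows that swapping the group at this position can shift the result by a large amount, but it does not show what chloro in particular does. The expectation is that this assay will show a weaker result for compound 3, by a 3.0-fold higher number from compound 2 to compound 3 (0.48 log units; beyond the scatter). Compound 3 is therefore estimated at 30000 nM, with a range from 8000 nM to 100000 nM.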

Compound 3, concentration for 50% growth inhibition: 17500 nM
Estimate against measurement, compound 3: 1.7-fold (0.23 log units) above; measured number inside the range.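

The step to chloro is a 1.8-fold higher number from compound 2 to compound 3 (0.25 log units; within the scatter), so in this assay methoxy and chloro on this aromatic carbon cannot be told apart, even though methoxy counts one hydrogen-bond acceptor and chloro none. Trifluoromethyl now stands apart from two groups rather than one, with an at least 5.7-fold lower number from compound 1 to compound 3 (0.75 log units; beyond the scatter). That step has at one end a limit of the assay and not a number, so its true size is uncertain: the limit of > 100000 nM in this assay, at which 1 of the 3 values shown sits.

The compounds shown leave open whether quite different groups on this carbon, such as an amine, a carboxylic acid or a longer chain, would give results like those of compound 2 and compound 3. They also leave open whether changes elsewhere on the shared core would alter the result.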